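The source may report more compounds than this note shows. Statements on the series, on what has been measured and on what is new or still open speak of the compounds shown alone.

Compound 2 `O=C(N/N=C/c1cccc(Br)c1)c1cnccn1` stands highest of the two compounds measured in an ADME assay on J774 cells (Mus musculus) for cytotoxicity, read by MTT assay, with a stated time of 48 h, tested at 50 ug/mL; a lower number here means a stronger effect, a higher number a weaker effect of the compound at the concentration tested: compound 2 gives 100%, while compound 1 `O=C(N/N=C/c1cccc(F)c1)c1cnccn1` gives 49%. Compound 3 `CCOc1cccc(/C=N/NC(=O)c2cnccn2)c1` has not yet been measured in this assay. It differs from compound 2 by ethoxy in place of bromo on an aromatic carbon. Within the data shown here, the only measured step that bears on this change is a number 51 percentage points higher from compound 1 to compound 2 (beyond the scatter), a swap of one halogen for another, so it gives little direct guidance for an ethoxy group. Compound 3 is therefore expected to shift only by a number 15 percentage points lower from compound 2 to compound 3 (beyond the scatter). The estimate for compound 3 is 85%, in a range from 50% to 100%.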

Compound 3, a percentage reported as activity, at one concentration (the size of the read-out at that concentration, not a potency): 74%
Estimate against measurement, compound 3: 11 percentage points above, within the range that was stated.
By their numbers in this assay, from the lowest: compound 1; then compound 3; then compound 2.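

In this assay, ethoxy in place of bromo gives a number 26 percentage points lower from compound 2 to compound 3 (beyond the scatter) and ethoxy in place of fluoro gives a number 25 percentage points higher from compound 1 to compound 3 (beyond the scatter) at this same place on the ring. The ethoxy compound therefore falls between the two halogen compounds, which shows that the read-out at this position also responds to a group that is not a halogen. Nothing measured here accounts for this order of the three groups. On these data alone, whether a longer alkoxy chain or an amine at this place would give a number near that of ethoxy stays open. So does whether the same order would hold elsewhere on the ring.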